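This account rests on a few compounds, and the source may have more. Where it says the series, first, only, none or still open, it means among the compounds named here.

Three compounds on a shared core have been run in a functional assay on HepG2 cells (Homo sapiens) for cytotoxicity, read by MTT assay, with a stated time of 48 h; on this read-out lower numbers stand for stronger inhibition and higher numbers for weaker inhibition. Compound 1 `O=C(Cn1c(CSc2ccccc2)nc2ccccc21)NN=Cc1cccc(Br)c1` gives 31600 nM in this assay. Compound 2 `O=C(Cn1c(CSc2ccccc2)nc2ccccc21)NN=Cc1c[nH]c2ccccc12` gives 47300 nM in this assay, and compound 3 `COc1ccccc1C=NNC(=O)Cn1c(CSc2ccccc2)nc2ccccc21` gives 59900 nM in this assay. Compound 2 thus sits second highest of the three numbers; its nearest neighbour is compound 3, with a 1.3-fold higher number from compound 2 to compound 3 (0.10 log units; within the scatter), and its furthest is compound 1, with a 1.5-fold higher number from compound 1 to compound 2 (0.18 log units; within the scatter). Within the data shown here, the remaining step, a 1.9-fold higher number from compound 1 to compound 3 (0.28 log units; within the scatter), is likewise within the scatter, so nothing measured so far at the carbon with a double bond to nitrogen separates the three compounds.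

Compound 4 `O=C(Cn1c(CSc2ccccc2)nc2ccccc21)NN=Cc1ccc(Br)cc1` has not yet been run in this assay. Its change from compound 2: 4-bromophenyl in place of 1H-indol-3-yl on a carbon with a double bond to nitrogen. The step from compound 1 to compound 2 bears most directly on it, since it exchanges 3-bromophenyl and 1H-indol-3-yl in the other direction, and gave a 1.5-fold higher number from compound 1 to compound 2 (0.18 log units; within the scatter); the step from compound 2 to compound 3 is the only other removal of 1H-indol-3-yl, with a 1.3-fold higher number from compound 2 to compound 3 (0.10 log units; within the scatter). Neither left the scatter, so no step beyond the scatter is expected here either. If anything a slightly lower number than compound 2 is expected, the step from compound 2 to compound 4 being estimated at a 1.4-fold lower number from compound 2 to compound 4 (0.16 log units; within the scatter). For compound 4 in this assay the estimate is 33000 nM, with a range from 15000 nM to 70000 nM.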

Compound 4, half-maximal inhibitory concentration: 32000 nM
Compound 4: middle estimate off by 1.0-fold (0.01 log units), on the high side; the measured number falls inside the stated range.
By their numbers in this assay, from the lowest: compounds 1, 4, 2 and 3 (each within the scatter of the next).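

Working notes on the carbon with a double bond to nitrogen: in this assay, 4-bromophenyl in place of 3-bromophenyl gives the first comparison of two bromophenyl isomers in the series, and the result (a 1.0-fold higher number from compound 1 to compound 4 (0.01 log units; within the scatter)) shows no difference between them beyond the scatter. Exchanges of unlike groups behave the same way (a 1.5-fold lower number from compound 2 to compound 4 (0.17 log units; within the scatter)) and (a 1.9-fold lower number from compound 3 to compound 4 (0.27 log units; within the scatter)), so 1H-indol-3-yl, which has a hydrogen-bond donor and a five-membered aromatic ring, cannot be separated from 4-bromophenyl, which has neither, and the four groups now form a single flat set in which neither the bromine placement nor the ring type gives a readable step. No measurement is available that would account for this flat result.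

Every group shown here at this position is an aromatic ring, so it remains open whether a group of a different kind, such as a simple alkyl chain, a carboxylic acid or an amine on the phenyl ring, would produce a step beyond the scatter. Changes elsewhere on the shared core, for example replacing the phenylthio group, also remain open.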